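Amine side chain: from compound 3 to compound 4

The source may report more compounds than this note shows. Statements on the series, on what has been measured and on what is new or still open speak of the compounds shown alone.

The series keeps a shared core and varies the amine on a saturated ring carbon, read in a functional assay on the whole organism for positive allosteric modulation, with Mus musculus as the target; on this read-out lower numbers stand for an effect already at smaller amounts and higher numbers for an effect only at larger amounts of compound. Compound 1 (`CCC(=O)N(c1ccc(Cl)c(Cl)c1)C1CCCC1N(CC)CC`) gives 0.1 mg/kg, compound 2 (`CCCN(CCC)C1CCCC1N(C(=O)CC)c1ccc(Cl)c(Cl)c1`) gives 2 mg/kg, and compound 3 (`CCC(=O)N(c1ccc(Cl)c(Cl)c1)C1CCCC1N(C)Cc1ccccc1`) gives 0.2 mg/kg. Compound 3 therefore sits with compound 1 and well apart from compound 2, as two steps show: a 2.0-fold higher number from compound 1 to compound 3 (0.30 log units; within the scatter), and a 10-fold lower number from compound 2 to compound 3 (1.00 log units; beyond the scatter).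

Compound 4 (`CCC(=O)N(c1ccc(Cl)c(Cl)c1)C1CCCC1N(C)CCCN(C)C`) carries 2-(dimethylamino)ethyl in place of phenyl on a saturated chain carbon bound to an amine nitrogen. Going by the values given here, no measured compound carries this group, so the earlier steps guide only the likely size. Among the compounds with values here, the amine swap leading to compound 2 was large, a 20-fold higher number from compound 1 to compound 2 (1.30 log units; beyond the scatter), while the one leading to compound 3 stayed within the scatter. A modest upward step is expected, estimated as a 4.0-fold higher number from compound 3 to compound 4 (0.60 log units; beyond the scatter). Compound 4 is estimated at 0.8 mg/kg, with an expected range from 0.15 mg/kg to 5 mg/kg.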

Compound 4, dose for half-maximal effect: 4 mg/kg
Estimate against measurement, compound 4: 5.0-fold (0.70 log units) below; low and high end bracket the measured number.
By their numbers in this assay, from the lowest: compounds 1 and 3 (each within the scatter of the next); then compounds 2 and 4 (each within the scatter of the next).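

In this assay, 2-(dimethylamino)ethyl in place of phenyl on a saturated chain carbon bound to an amine nitrogen gives a large step (a 20-fold higher number from compound 3 to compound 4 (1.30 log units; beyond the scatter)), so the tolerance seen for benzyl(methyl)amino does not extend to every longer amine side chain. Compound 4 also stands far from the diethylamino compound (a 40-fold higher number from compound 1 to compound 4 (1.60 log units; beyond the scatter)) but within the scatter of the dipropylamino compound (a 2.0-fold higher number from compound 2 to compound 4 (0.30 log units; within the scatter)), so two quite different amines share the same high range of doses. No evidence is available to explain these steps.

The change removes an aromatic ring and adds a nitrogen in one move, and the compounds shown do not separate the two. A plain butyl chain or a 3-phenylpropyl chain on the same methylamino nitrogen would bear on that question.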